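This account rests on a few compounds, and the source may have more. Where it says the series, first, only, none or still open, it means among the compounds named here.

In a functional assay on Huh-5-2 cells (Homo sapiens) for cytotoxicity, read by microscopy (on this read-out lower numbers stand for higher toxicity in this test and higher numbers for lower toxicity in this test), compound 1 `CC(=O)OC[C@H]1O[C@@H](n2c(SCc3cc4cc(Br)cc(Br)c4oc3=O)nc3cncnc32)[C@H](OC(C)=O)[C@@H]1OC(C)=O` gives 6000 nM, compound 2 `CC(=O)OC[C@H]1O[C@@H](n2c(SCc3cc4ccccc4oc3=O)nc3cncnc32)[C@H](O)[C@@H]1O` gives 8700 nM and compound 3 `COc1cccc2cc(CSc3nc4cncnc4n3[C@@H]3O[C@H](COC(C)=O)[C@@H](O)[C@H]3O)c(=O)oc12` gives 11000 nM. These three numbers lie within the usual scatter of one another, so compound 3 stands level with the other two.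

Compound 4 `COc1cccc2cc(CSc3nc4cncnc4n3[C@@H]3O[C@H](CO)[C@@H](O)[C@H]3O)c(=O)oc12` differs from compound 3 in one place: hydrogen in place of acetyl on an oxygen on a saturated carbon. In words, hydrogen sits in place of acetyl on an oxygen on a saturated carbon, which turns acetoxymethyl into hydroxymethyl.

Among the compounds with values here, only one single-place step has been measured so far, a 1.3-fold higher number from compound 2 to compound 3 (0.10 log units; within the scatter), and it is a different change: methoxy in place of hydrogen on an aromatic carbon. Within the data shown here, no measured step removes an acetyl, so the data give only indirect guidance. With all three numbers this close, no step beyond the scatter is expected in this assay, and no clear direction can be claimed. The expected step is a 1.2-fold higher number from compound 3 to compound 4 (0.07 log units; within the scatter). For compound 4 the estimated value is 13000 nM, with an expected range from 5000 nM to 35000 nM.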

Compound 4, half-maximal cytotoxic concentration in the Huh-5-2 assay: 47000 nM
Beside the measured number, compound 4's estimate is 3.6-fold (0.56 log units) below it, outside the stated range (above it).
By their numbers in the Huh-5-2 assay, from the lowest: compounds 1, 2 and 3 (each within the scatter of the next); then compound 4.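

Within the data shown here, in the Huh-5-2 assay, compound 3 gives 11000 nM and compound 4 gives 47000 nM so that taking the acetyl off this oxygen gives a 4.3-fold higher number from compound 3 to compound 4 (0.63 log units; beyond the scatter), the first step that lies beyond the scatter. Compounds 1, 2 and 3 all carry acetoxymethyl and stand level with one another, so only compound 4 shows that the change from acetoxymethyl to hydroxymethyl can move this read-out, here toward lower toxicity in this test. In a physicochemical assay for solubility, read by HPLC (a higher number here means a more soluble compound, a lower number a less soluble compound), compound 3 gives 216 ug/mL and compound 4 gives 224 ug/mL and the same change gives a 1.0-fold higher number from compound 3 to compound 4 (0.02 log units; within the scatter), so compound 3 and compound 4 stand level on that measure.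

Going by these compounds, it remains open whether a methyl ether or an amine at this position would give a similar number, and whether removing the acetyl from compound 2 would produce a similar step. Nothing shown here offers an explanation for the step in toxicity.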